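Compound 1 to compound 3: losing one double bond

The source may hold more compounds than are shown below. What is called first, only, known or untested is meant among the compounds shown, and "the series" means these compounds.

Compound 1 `CC1CC=C(C(=O)N(c2cc(C#CC(C)(C)C)sc2C(=O)O)C(C)C)CC1` was tested in an ADME assay on MT4 cells (Homo sapiens) for cytotoxicity, with a stated time of 5 days; on this read-out higher numbers stand for lower toxicity in this test and lower numbers for higher toxicity in this test. In this assay compound 1 gives > 20000 nM, which is a limit and not a number. Compound 2 `CC(C)(C)C#Cc1cc(N(C(=O)[C@H]2CC[C@H](C)CC2)[C@H]2CC[C@H](Oc3cccnc3)CC2)c(C(=O)O)s1`, which carries 4-methylcyclohexyl on a carbonyl carbon, gives > 20000 nM, also a limit. Neither compound therefore has an exact value, and both sit at the limit of > 20000 nM in this assay, at which 2 of the 2 values shown sit.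

Compound 3 `CC(C)N(c1cc(C#CC(C)(C)C)sc1C(=O)O)C(=O)[C@H]1CC[C@H](C)CC1` has not yet been measured. It differs from compound 1 in one place: 4-methylcyclohexyl in place of 4-methylcyclohex-1-en-1-yl on a carbonyl carbon. Put simply, 4-methylcyclohexyl stands in place of 4-methylcyclohex-1-en-1-yl on a carbonyl carbon, so the double bond outside aromatic rings is gone. For the measured compounds named here, no measured pair shows this change on its own, so any forecast is tentative. The expectation rests on compound 2, whose > 20000 nM is a limit as well. The estimated step, a step that the limit leaves unreadable from compound 1 to compound 3, is expected to stay within the usual scatter, with no direction favoured. Compound 3 may well be reported only as a limit too. For compound 3 the expected value is 25000 nM, with an estimated range of 12000 nM to 50000 nM.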

Compound 3, half-maximal cytotoxic concentration: > 20000 nM
Compound 3: no number, only a limit; the forecaster's own chance of this, stated with the estimate: 80%; the middle value does not contradict the limit.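

In this assay compound 3 gives > 20000 nM, which is a limit and not a number. For the compounds shown here, compound 1 also has only a limit, so no step from compound 1 to compound 3 can be read: the limit of > 20000 nM in this assay, at which 3 of the 3 values shown sit. The compounds shown leave open whether swapping 4-methylcyclohex-1-en-1-yl for 4-methylcyclohexyl changes the half-maximal cytotoxic concentration at all in this assay.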